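Adding a Chain to the Amine Nitrogen of Compound 1

A few compounds are considered here, and "the series" means these few. Any claim that something is new, unique, unknown or untested is made for them only; others in the source may bear on it.

Measured compounds:
compound 1 `Nc1ccc(C2=NNC(=O)CC2)cc1`: 46.4 ug/mL
compound 2 `CN1N=C(c2ccc(NC(=O)CCl)cc2)CCC1=O`: > 46.4 ug/mL

Of the compounds shown here, two have been tested in a functional assay for inhibition, with Homo sapiens as the target; on this read-out higher numbers stand for an effect only at larger amounts of compound and lower numbers for an effect already at smaller amounts. Among the measured compounds shown here, compound 1 is the only one with an actual number: in this assay compound 1 gives 46.4 ug/mL. Compound 2 sits at the limit of > 46.4 ug/mL in this assay, at which 1 of the 2 values shown sits, which is a limit of the assay rather than a number, so in this assay compound 2 is recorded as > 46.4 ug/mL and nothing closer can be said about it. For the measured compounds named here, no pair of measured compounds differs in a single place, so no measured step exists to lean on.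

Compound 3 `CCCNCC(=O)Nc1ccc(C2=NNC(=O)CC2)cc1` has not yet been measured. It differs from compound 1 in one place: ((propylamino)methyl)carbonyl in place of hydrogen on a nitrogen on an aromatic ring. Going by the values given here, with no measured step to guide the direction, the expected step of a 1.1-fold higher number from compound 1 to compound 3 (0.03 log units; within the scatter) is taken to lie within the usual scatter, with some chance that the assay again reports only a limit. For compound 3 the value in this assay is estimated at 50 ug/mL, in a range from 15 ug/mL to 150 ug/mL.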

Compound 3, half-maximal effective concentration: about 46.4 ug/mL
Beside the measured number, compound 3's estimate is 1.1-fold (0.03 log units) above it, and the stated range covers the measured number.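

In this assay, among the compounds shown here, putting ((propylamino)methyl)carbonyl in place of hydrogen on a nitrogen on an aromatic ring gives no change at the digits printed from compound 1 to compound 3 (within the scatter), and this is the first measured step between two compounds that differ in one place. It shows that this nitrogen can carry a chain of 7 heavy atoms while compound 3 still returns an actual number, with no measurable change from the parent compound in this one assay. Compound 2 remains a limit of the assay rather than a number: the limit of > 46.4 ug/mL in this assay, at which 1 of the 3 values shown sits.

A single step with no change does not show how much this position tolerates, or whether any change here could move the number beyond the scatter in either direction. It also leaves open what a longer chain, a carboxylic acid or a piperidine ring in place of the propylamino part would do, and whether the amine of the new group or its carbonyl matters at all for the read-out.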